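A few compounds are considered here, and "the series" means these few. Any claim that something is new, unique, unknown or untested is made for them only; others in the source may bear on it.

In an in vivo ADME assay on the whole organism (plasma, strain Sprague-Dawley) for pharmacokinetics, with Rattus norvegicus as the target (a lower number here means slower removal, a higher number faster removal of the compound), compound 1 `CN[C@@H](C)c1ccc(N2CC[C@H](NS(=O)(=O)c3ccc4cc(Cl)ccc4c3)C2=O)c(F)c1` gives 1.6 mL/min/kg, the lowest of the three numbers in hand. Compound 2 `CN(C)[C@H]1CCc2cc(N3CC[C@H](NS(=O)(=O)c4ccc5cc(Cl)ccc5c4)C3=O)ccc21` gives 6 mL/min/kg and compound 3 `CN1CCCC1c1ccc(N2CC[C@H](NS(=O)(=O)/C=C/c3ccc(Cl)s3)C2=O)c(F)c1` gives 11 mL/min/kg, both higher beyond the scatter. Compound 4 `O=C1[C@@H](NS(=O)(=O)c2ccc3cc(Cl)ccc3c2)CCN1c1ccc([C@H]2CCCN2)cc1F` carries pyrrolidin-2-yl in place of 1-(methylamino)ethyl on an aromatic carbon of the core of compound 1: pyrrolidin-2-yl in place of 1-(methylamino)ethyl on an aromatic carbon. For the measured compounds named here, no measured pair isolates this change, and compounds 2 and 3 each differ from compound 1 in more than one place. A modest rise in this assay is expected, near the edge of the scatter, since compound 1 at 1.6 mL/min/kg sits at the bottom of the series. The expected step is a 1.9-fold higher number from compound 1 to compound 4 (0.27 log units; within the scatter). For compound 4 the estimated clearance is 3 mL/min/kg, with an expected range of 1.2 mL/min/kg to 8 mL/min/kg.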

Compound 4, clearance: 2.6 mL/min/kg
Compound 4: middle estimate off by 1.2-fold (0.06 log units), on the high side; the measured number falls inside the stated range.
By their numbers in this assay, from the lowest: compounds 1 and 4 (each within the scatter of the next); then compounds 2 and 3 (each within the scatter of the next).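

For the compounds shown here, compounds 1 and 4 form the first pair that differs in one place, and in this assay the step is a 1.6-fold higher number from compound 1 to compound 4 (0.21 log units; within the scatter). At this aromatic carbon, meta to a fluoro group and para to a large group, pyrrolidin-2-yl and 1-(methylamino)ethyl cannot be told apart in this read-out. No supporting data bear on the size of this step.

Open, on these data alone, is whether a non-basic group such as a carboxylic acid or an amide at this carbon would stay as close. Also open, as far as these compounds go, is how the opposite stereocentre of pyrrolidin-2-yl would read.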